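Imines of pyridinylmethanamine in the maximal electroshock model

A few compounds are considered here, and "the series" means these few. Any claim that something is new, unique, unknown or untested is made for them only; others in the source may bear on it.

Compound 1 `Clc1ccccc1/C=N/Cc1cccnc1`: 30 mg/kg
Compound 2 `C(=N/Cc1cccnc1)\c1ccccc1`: 30 mg/kg

The two measured compounds share one core and differ only in a single substituent on the phenyl ring. In a functional assay on the whole organism (strain Swiss albino) with Mus musculus as the target, in the maximal electroshock model, with a stated time of 4 h (a lower number here means that less compound is needed, a higher number that more compound is needed for the effect), compound 1 gives 30 mg/kg, and in this assay compound 2 gives 30 mg/kg. The one measured step, no change at the digits printed from compound 1 to compound 2 (within the scatter), shows that removing the chloro group left the minimum effective dose level; compound 2 therefore stands level with compound 1 on the numbers shown, within the scatter.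

Compound 3 `COc1ccccc1/C=N/Cc1cccnc1` has not yet been measured. It differs from compound 2 in one place: methoxy in place of hydrogen on an aromatic carbon. Within the data shown here, no measured step covers a methoxy group entering at this position; the only step that bears on it is the one from compound 1 to compound 2, which put a different group at the same aromatic carbon and was flat. By that analogy, the step of no change at the digits printed from compound 2 to compound 3 (within the scatter) is expected to show no change beyond the scatter. Compound 3 is therefore estimated at 30 mg/kg, with a range from 10 mg/kg to 100 mg/kg.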

Compound 3, minimum effective dose: 30 mg/kg
Compound 3: the middle estimate sits on the measured number at the digits printed, and the stated range covers the measured number.
By their numbers in this assay, from the lowest: compounds 1, 2 and 3 (each within the scatter of the next).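

Compound 3 puts methoxy, a group of 2 heavy atoms with 1 hydrogen-bond acceptor, on the aromatic carbon ortho to a group of 9 heavy atoms, and in this assay this gives no change at the digits printed from compound 2 to compound 3 (within the scatter) and, for the direct exchange of chloro for methoxy, no change at the digits printed from compound 1 to compound 3 (within the scatter) as well. Among these compounds, until now this carbon had been seen only with hydrogen and chloro; it now carries three different groups, one of them containing oxygen, and all three compounds stand level in the minimum effective dose, with none of them going against that. Nothing measured here offers an account of this level result.

Going by these compounds, whether the level holds for an amine, a carboxylic acid or a longer chain such as butoxy on this same aromatic carbon stays open, as does the outcome of placing chloro or methoxy on other carbons of that ring. The three compounds also share a single read-out at one stated time, so they leave open whether the groups would remain level at any other time after dosing.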